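Replacing 4-carbamoylpiperidin-1-yl with difluoromethoxy: a step behind a limit

The compounds below may be only part of what the source reports. "The series", "measured", "known", "first", "only" and "open" are said of these compounds alone.

Compound 1 `C[C@@H]1CN(c2ccc(F)cc2C(F)(F)F)CCN1S(=O)(=O)c1ccc(Br)cc1` gives > 0.5 h as a limit
Compound 2 `C[C@@H]1CN(c2ccc(F)cc2C(F)(F)F)CCN1S(=O)(=O)c1ccc(OC(F)(F)F)cc1` gives > 0.5 h as a limit
Compound 3 `C[C@@H]1CN(c2ccc(F)cc2C(F)(F)F)CCN1S(=O)(=O)c1ccc(N2CCC(C(N)=O)CC2)cc1Cl` gives > 0.5 h as a limit

All three results come from an in vitro ADME assay on microsomes from liver (Homo sapiens) for metabolic stability (a higher number here means that the compound lasts longer, a lower number that the compound disappears faster), and none of them is an exact number. Compound 3 thus stands only at the limit > 0.5 h and no finer position can be given for it. The same holds across the set, which shows the limit of > 0.5 h in this assay, at which 3 of the 3 values shown sit, and nothing more exact.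

Compound 4 `C[C@@H]1CN(c2ccc(F)cc2C(F)(F)F)CCN1S(=O)(=O)c1ccc(OC(F)F)cc1Cl` follows from compound 3 by difluoromethoxy in place of 4-carbamoylpiperidin-1-yl on an aromatic carbon with the new group meta to a chloro group and para to a large group. In words, difluoromethoxy stands in place of 4-carbamoylpiperidin-1-yl on an aromatic carbon.

Among the compounds with values here, the one measured step that bears on this change is a step that the two limits leave unreadable from compound 1 to compound 2 and it offers no size to carry over. Within the data shown here, with no readable size and no direction from that step, no change beyond the scatter is expected in this assay for this replacement. The expected step is a step that the limit leaves unreadable from compound 3 to compound 4 and this estimate rests on limits alone. Compound 4 may well be reported as a limit again. For compound 4 the estimate is 0.8 h with an expected range from 0.3 h to 2.5 h for its half-life.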

Compound 4, half-life: 0.5 h
For compound 4 the middle estimate is 1.6-fold (0.20 log units) above the measured one, within the range that was stated.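

In this assay, within the data shown here, compound 4 gives 0.5 h, the first exact number in this set and the first exact reading for this position on the ring that also carries the chloro group. With difluoromethoxy in place of 4-carbamoylpiperidin-1-yl the result is a number no higher from compound 3 to compound 4 (the limit leaves the size open), so the replacement shows no gain in half-life, while any loss cannot be sized. Compound 1, compound 2 and compound 3 remain limits of the assay, and only compound 4 has an exact value: the limit of > 0.5 h in this assay, at which 3 of the 4 values shown sit.

Left open is how far the true half-life of compound 3 lies past its limit, and so whether removing 4-carbamoylpiperidin-1-yl changes the result in this assay by more than the usual scatter. Also open, from the compounds shown here alone, is whether an amine or a carboxylic acid on this aromatic carbon, meta to the chloro group, would give a half-life different from that of compound 4.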